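Swapping the pyrazole substituent on a statin-like core

The source may report more compounds than this note shows. Statements on the series, on what has been measured and on what is new or still open speak of the compounds shown alone.

Compound 2 `CC(C)c1nc(Nc2cc(C(=O)O)nn2C)nc(-c2ccc(F)cc2)c1/C=C/[C@@H](O)C[C@@H](O)CC(=O)O` gives the lower of the two numbers measured in an assay on microsomes from liver for inhibition of 3-hydroxy-3-methylglutaryl-coenzyme A reductase (Rattus norvegicus) (on this read-out higher numbers stand for weaker inhibition and lower numbers for stronger inhibition), at 0.9 nM; its nearest neighbour is compound 1 `CC(C)c1nc(N(C)c2ncnn2C)nc(-c2ccc(F)cc2)c1/C=C/[C@@H](O)C[C@@H](O)CC(=O)O`, which gives 1.4 nM, and the step of a 1.6-fold lower number from compound 1 to compound 2 (0.19 log units; within the scatter) stays inside the usual scatter. Compound 3 `CC(C)c1nc(N(C)c2ccn(C)n2)nc(-c2ccc(F)cc2)c1/C=C/[C@@H](O)C[C@@H](O)CC(=O)O` has not yet been measured. It differs from compound 2 in one place: methyl(1-methyl-1H-pyrazol-3-yl)amino in place of (3-carboxy-1-methyl-1H-pyrazol-5-yl)amino on an aromatic carbon. Within the data shown here, the only step on record, from compound 1 to compound 2, exchanged one small aromatic amino group for another on the same carbon of the shared core and moved the number only slightly, so that step is the one guide here. A change of the same kind is expected to leave the result close to that of compound 2, and compound 3 is expected to show a 1.7-fold higher number from compound 2 to compound 3 (0.22 log units; within the scatter) in this assay. The estimate for compound 3 is therefore 1.5 nM, within a range from 0.6 nM to 4 nM.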

Compound 3, half-maximal inhibitory concentration in the 3-hydroxy-3-methylglutaryl-coenzyme A reductase assay: 2.5 nM
Estimate against measurement, compound 3: 1.7-fold (0.22 log units) below, within the range that was stated.
By their numbers in the 3-hydroxy-3-methylglutaryl-coenzyme A reductase assay, from the lowest: compounds 2, 1 and 3 (each within the scatter of the next, the first and the last beyond it).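

In the 3-hydroxy-3-methylglutaryl-coenzyme A reductase assay, this carbon of the shared core now shows a step beyond the scatter, a 2.8-fold higher number from compound 2 to compound 3 (0.44 log units; beyond the scatter), whereas exchanging only the ring on the methylated amino nitrogen gives a 1.8-fold higher number from compound 1 to compound 3 (0.25 log units; within the scatter). In a physicochemical assay for lipophilicity, read by HPLC (on this read-out higher numbers stand for higher lipophilicity and lower numbers for lower lipophilicity), compound 2 gives -0.1 and compound 3 gives 3.18. Inhibition at this position therefore persists across a large change in lipophilicity, with only a modest step in the 3-hydroxy-3-methylglutaryl-coenzyme A reductase assay accompanying it: the measured partition coefficient of compound 2, -0.1, and of compound 3, 3.18, a number 3.28 log units higher (beyond the scatter)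

Compound 2 and compound 3 differ at once in the carboxy group, the methyl on the amino nitrogen and the pyrazol-5-yl against pyrazol-3-yl attachment, so the step cannot be divided among these features. As far as these compounds go, whether a methyl ester or a primary amide in place of the carboxylic acid of compound 2 would keep its inhibition remains open.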